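Swapping an Alkyne Arm for a Chloroaryl Ring

The source may report more compounds than this note shows. Statements on the series, on what has been measured and on what is new or still open speak of the compounds shown alone.

Measured compounds:
compound 1 `Nc1ncnn2c([C@@H]3O[C@H](CO)[C@@H](O)[C@H]3O)cc(C#CC3CC3)c12` — 40 nM
compound 2 `Nc1ncnn2c([C@@H]3O[C@H](CO)[C@@H](O)[C@H]3O)cc(C#Cc3ccccc3)c12` — > 100000 nM (a limit)

Going by the values given here, in a functional assay on K562 cells (Homo sapiens) for antiproliferative activity, with a stated time of 72 h (on this read-out lower numbers stand for stronger inhibition and higher numbers for weaker inhibition), compound 1 gives 40 nM and is the only compound with a plain number. Compound 2 reaches only a limit of the assay, > 100000 nM. The step of an at least 2500-fold higher number from compound 1 to compound 2 (3.39 log units; beyond the scatter) shows how sharply an aromatic ring in that arm cuts activity. Compound 3 `Nc1ncnn2c([C@@H]3O[C@H](CO)[C@@H](O)[C@H]3O)cc(-c3ccc(Cl)cc3)c12` is not yet measured; it carries 4-chlorophenyl in place of 2-cyclopropylethynyl on an aromatic carbon. Among the compounds with values here, only that one measured step bears on this change, and it was large, so a large loss in this assay is expected, a 1000-fold higher number from compound 1 to compound 3 (3.00 log units; beyond the scatter). Compound 3 is therefore expected to give about 40000 nM, between 4000 nM and 150000 nM, quite possibly ending at the limit of > 100000 nM in this assay, at which 1 of the 2 values shown sits.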

Compound 3, half-maximal inhibitory concentration: 47800 nM
Beside the measured number, compound 3's estimate is 1.2-fold (0.08 log units) below it, and the stated range covers the measured number.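

In this assay, replacing 2-cyclopropylethynyl with 4-chlorophenyl gives a 1200-fold higher number from compound 1 to compound 3 (3.08 log units; beyond the scatter), so an aromatic ring on this carbon goes with weak activity both with and without the triple bond. Replacing 2-phenylethynyl with 4-chlorophenyl gives an at least 2.0-fold lower number from compound 2 to compound 3 (0.32 log units; beyond the scatter), and compound 3 has a plain number. Compound 2 reaches only a limit: the limit of > 100000 nM in this assay, at which 1 of the 3 values shown sits.

As far as these compounds go, whether the triple bond or the cyclopropyl ring matters more for the activity of compound 1 remains open. So does the effect of an amine or a longer alkyl chain on this carbon.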